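The source may hold more compounds than are shown below. What is called first, only, known or untested is meant among the compounds shown, and "the series" means these compounds.

Three compounds of the series have numbers in an assay on HEK293 cells for positive allosteric modulation of metabotropic glutamate receptor 2 (Rattus norvegicus), read by thallium flux; on this read-out higher numbers stand for an effect only at larger amounts of compound and lower numbers for an effect already at smaller amounts. Compound 1 `O=C(O)c1cc(-c2cccc(COc3ccc4c(=O)n(C5CCCC5)oc4c3)c2)ccc1Cl` gives 310 nM. Compound 2 `O=C(O)c1cc(-c2cccc(COc3ccc4c(c3)CN(c3ccccc3)C4=O)c2)ccc1Cl` gives 260 nM. Compound 3 `CC(C)N1Cc2cc(OCc3cccc(-c4ccc(Cl)c(C(=O)O)c4)c3)ccc2C1=O` gives 70 nM, the lowest of the three numbers; the nearest is compound 2 and the furthest is compound 1, and both gaps lie beyond the scatter. Going by the values given here, the only single-point step measured so far sits on the amide-type nitrogen in a ring: a 3.7-fold lower number from compound 2 to compound 3 (0.57 log units; beyond the scatter), with isopropyl in place of phenyl there. Compound 4 `CC(C)CCN1Cc2cc(OCc3cccc(-c4ccc(Cl)c(C(=O)O)c4)c3)ccc2C1=O` keeps the core of compound 3 and differs from it only by isopentyl in place of isopropyl on an amide-type nitrogen in a ring. Among the compounds with values here, the change touches the same nitrogen substituent, but no measured pair compares two alkyl groups at that place, so the size of the step is open; the one step on record shows that this substituent can move the number modestly. A step within the scatter, or a small rise, is expected: a 1.4-fold higher number from compound 3 to compound 4 (0.15 log units; within the scatter). For compound 4 in this assay the estimate is 100 nM, with a range of 35 nM to 300 nM.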

Compound 4, half-maximal effective concentration: 60 nM
For compound 4 the middle estimate is 1.7-fold (0.22 log units) above the measured one; the range from low to high includes it.
By their numbers in this assay, from the lowest: compounds 4 and 3 (each within the scatter of the next); then compounds 2 and 1 (each within the scatter of the next).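

Going by these compounds alone, the first comparison of two alkyl groups on the amide-type nitrogen in a ring, read in this assay, gives a 1.2-fold lower number from compound 3 to compound 4 (0.07 log units; within the scatter), so isopentyl and isopropyl cannot be told apart here despite 5 heavy atoms against 3. Phenyl is a different matter: a 4.3-fold lower number from compound 2 to compound 4 (0.64 log units; beyond the scatter), which matches the earlier 3.7-fold lower number from compound 2 to compound 3 (0.57 log units; beyond the scatter), and both alkyl groups thus stand apart from phenyl, with no compound on this core going against that. No supporting data on hand bear on why the numbers fall this way.

From the compounds shown here alone, whether a longer chain, a cyclohexyl ring or a chain ending in an amine would hold the number at this level remains open. Compound 1 differs from the others in more than one place and so adds nothing on this nitrogen substituent.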